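This account rests on a few compounds, and the source may have more. Where it says the series, first, only, none or still open, it means among the compounds named here.

Compound 1, `CC1(C)Oc2ccc(C#N)cc2[C@@H](n2cccc2)[C@@H]1O`, in a functional assay (Trachealis) for inhibition, with Cavia porcellus as the target (a lower number here means a stronger inhibitor, a higher number a weaker inhibitor), reaches only the limit > 20000 nM.
Compound 2, `CC1(C)Oc2ccc(C#N)cc2[C@@H](n2cccc2[N+](=O)[O-])[C@@H]1O`, gives 370 nM in this assay.
Compound 3, `CC1(C)C=C(n2ccc([N+](=O)[O-])c2)c2cc(C#N)ccc2O1`, gives 1020 nM in this assay.

The change from compound 2 to compound 1 is hydrogen in place of nitro on an aromatic carbon. It gave an at least 54-fold higher number from compound 2 to compound 1 (1.73 log units; beyond the scatter). Compound 1 sits at the limit of > 20000 nM in this assay, at which 1 of the 3 values shown sits. Compound 3 carries the same nitro but on a different core; the difference between the two cores is not broken down here. Compound 4, `CC1(C)C=C(n2cccc2)c2cc(C#N)ccc2O1`, is not yet measured and differs from compound 3 by hydrogen in place of nitro on an aromatic carbon. This is the same kind of change as that from compound 2 to compound 1, though not the same: in compound 3 the nitro sits two ring bonds from the ring nitrogen and two ring bonds from the ring atom that bears a large group, whereas in compound 2 it is next to the ring nitrogen and next to the ring atom that bears a large group. Because the earlier removal gave an at least 54-fold higher number from compound 2 to compound 1 (1.73 log units; beyond the scatter), a loss of similar size is expected here, namely a 29-fold higher number from compound 3 to compound 4 (1.47 log units; beyond the scatter). In this assay compound 4 is therefore estimated at about 30000 nM, with a real chance that only a limit is reported.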

Compound 4, half-maximal inhibitory concentration: 4080 nM
Compound 4: middle estimate off by 7.4-fold (0.87 log units), on the high side; measured number below the stated range.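

Hydrogen in place of nitro again gives a weaker inhibitor in this assay, with a 4.0-fold higher number from compound 3 to compound 4 (0.60 log units; beyond the scatter). The direction of the change carries over from one core to the other, but its size does not: the same change on two cores in this assay, an at least 54-fold higher number (1.73 log units; beyond the scatter) from compound 2 to compound 1 and a 4.0-fold higher number (0.60 log units; beyond the scatter) from compound 3 to compound 4, at least 13-fold (1.13 log units) apart, beyond the scatter of two such steps. For compound 1, > 20000 nM is a limit of the assay and not a number, and the two pairs differ both in core and in where the nitro sits on the ring, so these results cannot show which of the two differences sets the gap.

On these data alone, it remains open what the same change does when the nitro sits at the same ring place on both cores. As far as these compounds go, it is also open whether a carboxylic acid or an amine in place of the nitro would hold the activity.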